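The source may report more compounds than this note shows. Statements on the series, on what has been measured and on what is new or still open speak of the compounds shown alone.

Measured compounds:
- Compound 1 `CC(C)[C@@H]1CC[C@@H](C)C[C@@]12N(C)C(=O)[C@@H]1[C@H]3C(=O)N(C)C(=O)[C@H]3ON12`: in a functional assay, read by spectrophotometry, with a stated time of 2 h (a lower number here means a stronger inhibitor, a higher number a weaker inhibitor), compound 1 gives 1400 ug/mL.
- Compound 2 `CC(C)[C@@H]1CC[C@@H](C)C[C@@]12N(C)C(=O)[C@@H]1[C@H]3C(=O)N(c4ccccc4)C(=O)[C@H]3ON12`: in this assay compound 2 gives 2250 ug/mL.
- Compound 3 `Cc1cccc(N2C(=O)[C@H]3[C@H](ON4[C@@H]3C(=O)N(C)[C@@]43C[C@H](C)CC[C@H]3C(C)C)C2=O)c1`: in this assay compound 3 gives 2700 ug/mL.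

Compound 3 carries the highest of the three numbers, but its separation from the others is small: a 1.2-fold higher number from compound 2 to compound 3 (0.08 log units; within the scatter), and a 1.9-fold higher number from compound 1 to compound 3 (0.29 log units; within the scatter). For the measured compounds named here, no compound can be set apart from the others on these numbers.

Compound 4 `CC(C)[C@@H]1CC[C@@H](C)C[C@@]12N(C)C(=O)[C@@H]1[C@H]3C(=O)N(c4ccc5ccccc5c4)C(=O)[C@H]3ON12` differs from compound 3 in one place: naphthalen-2-yl in place of 3-methylphenyl on an amide-type nitrogen in a ring. Going by the values given here, the steps that bear on this change are those that alter the group on the same amide-type nitrogen. Replacing methyl by an aromatic ring gave a 1.6-fold higher number from compound 1 to compound 2 (0.21 log units; within the scatter); adding methyl on that ring gave a 1.2-fold higher number from compound 2 to compound 3 (0.08 log units; within the scatter). Both stay within the scatter, so a further enlargement to a second fused aromatic ring is expected to give at most a small step, if anything toward a higher number.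

For compound 4 the expected step is a 1.2-fold higher number from compound 3 to compound 4 (0.07 log units; within the scatter). Compound 4 is therefore estimated at 3200 ug/mL, with a range from 1500 ug/mL to 7000 ug/mL.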

Compound 4, half-maximal inhibitory concentration: 2520 ug/mL
For compound 4 the middle estimate is 1.3-fold (0.10 log units) above the measured one, and the stated range covers the measured number.
By their numbers in this assay, from the lowest: compounds 1, 2, 4 and 3 (each within the scatter of the next).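

With naphthalen-2-yl on the amide-type nitrogen in a ring, the group grows from one six-membered aromatic ring of carbon only to two, and in this assay this gives a 1.1-fold lower number from compound 3 to compound 4 (0.03 log units; within the scatter) in place of 3-methylphenyl and a 1.1-fold higher number from compound 2 to compound 4 (0.05 log units; within the scatter) in place of phenyl. Even in place of methyl the step is a 1.8-fold higher number from compound 1 to compound 4 (0.26 log units; within the scatter) and stays small, so the four groups shown at this position cannot be told apart on these numbers, and adding a second fused aromatic ring brings no separation. No measured evidence bears on why this position gives so little difference.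

As far as these compounds go, whether an amine, a carboxylic acid or a longer alkyl chain on this nitrogen would move the number beyond the scatter remains open. Also open, from the compounds shown here alone, is whether any change elsewhere on the shared core would do so.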